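The source may hold more compounds than are shown below. What is called first, only, known or untested is meant among the compounds shown, and "the series" means these compounds.

In a functional assay on OVCAR-3 cells (Homo sapiens) for antiproliferative activity, read by MTT assay, with a stated time of 24 h (on this read-out higher numbers stand for weaker inhibition and lower numbers for stronger inhibition), compound 3 `Cc1ccccc1NNC(=O)c1ccccc1NS(=O)(=O)c1cnc(O)nc1O` gives only a limit and no number, > 20000 nM. This is the limit of > 20000 nM in this assay, at which 1 of the 3 values shown sits. Compound 4 `O=C(NNc1ccc(F)cc1)c1ccccc1NS(=O)(=O)c1cnc(O)nc1O` keeps the core of compound 3 and carries 4-fluorophenyl in place of 2-methylphenyl on an amine nitrogen.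

The nearest numbers come from two compounds with a different core. In this assay, compound 1 `O=C(NNc1cccc(Cl)c1)c1cccc(NS(=O)(=O)c2cnc(O)nc2O)c1` gives 8040 nM, and compound 2 `O=C(NNc1ccccc1F)c1cccc(NS(=O)(=O)c2cnc(O)nc2O)c1` gives 17000 nM. Among the compounds with values here, one measured step bears on the change, as it also swaps the aryl group on that amine nitrogen: a 2.1-fold higher number from compound 1 to compound 2 (0.33 log units; beyond the scatter). It is modest, and it comes from the other core, so it supports only a small expected step and says little about direction. A slight move toward stronger inhibition is expected, since the values of compound 1 and compound 2 both lie on that side of the limit, though compound 4 may also end at the limit. The expected step is an at least 1.3-fold lower number from compound 3 to compound 4 (0.12 log units; that floor lies within the scatter). The estimate for compound 4 is 15000 nM. The expected range runs from 6000 nM to 32000 nM.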

Compound 4, half-maximal inhibitory concentration: > 20000 nM
Compound 4: only a limit was reported (the forecaster's own chance of this, stated with the estimate: 40%); at least 1.3-fold (0.12 log units) between middle value and limit.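

Compound 3 and compound 4 both end at a limit in this assay, so no step can be read between them: the limit of > 20000 nM in this assay, at which 2 of the 4 values shown sit.

The compounds shown leave open whether 4-fluorophenyl in place of 2-methylphenyl on an amine nitrogen changes inhibition at all on this core.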